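Urea series: isomer of compound 2 in FAAH assay

The source may hold more compounds than are shown below. What is called first, only, known or untested is meant among the compounds shown, and "the series" means these compounds.

compound 1 `O=C(Nc1noc2cccnc12)N1CCN(Cc2cccc(Oc3ccc(Cl)cc3)c2)CC1` 22 nM
compound 2 `O=C(Nc1cccn2ccnc12)N1CCN(Cc2cccc(Oc3ccc(Cl)cc3)c2)CC1` 3500 nM

Going by the values given here, in an assay on isolated protein for inhibition of Fatty-acid amide hydrolase 1 (Rattus norvegicus), with a stated time of 60 min (a higher number here means a weaker inhibitor, a lower number a stronger inhibitor), compound 2 gives the higher of the two numbers; the only measured step, a 160-fold higher number from compound 1 to compound 2 (2.20 log units; beyond the scatter), is large and runs away from compound 1. Compound 3 `O=C(Nc1ccn2ccnc2c1)N1CCN(Cc2cccc(Oc3ccc(Cl)cc3)c2)CC1` keeps the same atoms as compound 2 but joins them differently: a group of 9 heavy atoms (7 carbon, 2 nitrogen; one five-membered aromatic ring with 2 hetero atoms, one six-membered aromatic ring with 1 hetero atom) in place of a group of 9 heavy atoms (7 carbon, 2 nitrogen; one five-membered aromatic ring with 2 hetero atoms, one six-membered aromatic ring with 1 hetero atom), on an amide-type nitrogen. Among the compounds with values here, no measured step bears on this rearrangement, since a 160-fold higher number from compound 1 to compound 2 (2.20 log units; beyond the scatter) swaps a different bicyclic group. The expectation for compound 3 is therefore no change beyond the scatter, a 1.2-fold lower number from compound 2 to compound 3 (0.07 log units; within the scatter), with wide uncertainty. Compound 3 is estimated at 3000 nM, range 500 nM to 15000 nM.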

Compound 3, half-maximal inhibitory concentration: 2600 nM
Compound 3: middle estimate off by 1.2-fold (0.06 log units), on the high side; the measured number falls inside the stated range.
By their numbers in this assay, from the lowest: compound 1; then compounds 3 and 2 (each within the scatter of the next).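

In this assay, rejoining the same atoms in the group on the amide-type nitrogen gives no change beyond the scatter, a 1.3-fold lower number from compound 2 to compound 3 (0.13 log units; within the scatter). Set against compound 1, the new group stands as far off as the earlier one, a 120-fold higher number from compound 1 to compound 3 (2.07 log units; beyond the scatter), so the large gap is not confined to a single arrangement of these atoms. Nothing measured explains this gap or the lack of a change between the two isomers. From the compounds shown here alone, what stays open is how a plain phenyl or a pyridine on this nitrogen would compare with compound 1.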